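This account rests on a few compounds, and the source may have more. Where it says the series, first, only, none or still open, it means among the compounds named here.

Three compounds built on one shared core were tested in an ADME assay on HEK293 cells (Homo sapiens) for cytotoxicity, read by MTT assay, with a stated time of 24 h; on this read-out lower numbers stand for stronger inhibition and higher numbers for weaker inhibition. Compound 1 `CN(C)CCCNc1nc2cc([N+](=O)[O-])ccc2nc1NCc1ccc(C(F)(F)F)cc1` gives 5.66 ug/mL in this assay, the lowest of the three numbers. Compound 2 `COc1ccc(CNc2nc3ccc([N+](=O)[O-])cc3nc2NCCCN(C)C)cc1` gives 38.6 ug/mL, and compound 3 `COc1ccccc1CNc1nc2ccc([N+](=O)[O-])cc2nc1NCCCN(C)C` gives 36.1 ug/mL. Both differ from compound 1 only in the group carried on the saturated chain carbon bound to a nitrogen on the aromatic ring: there is a 6.8-fold higher number from compound 1 to compound 2 (0.83 log units; beyond the scatter) and a 6.4-fold higher number from compound 1 to compound 3 (0.80 log units; beyond the scatter), while between the two methoxy compounds there is a 1.1-fold lower number from compound 2 to compound 3 (0.03 log units; within the scatter).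

Compound 4 `CN(C)CCCNc1nc2cc([N+](=O)[O-])ccc2nc1NCc1cc(F)cc(C(F)(F)F)c1` has not yet been measured. It differs from compound 1 in one place: 3-fluoro-5-(trifluoromethyl)phenyl in place of 4-(trifluoromethyl)phenyl on a saturated chain carbon bound to a nitrogen on an aromatic ring. The trifluoromethyl stays, and one further fluorine is added to the ring. Among the compounds with values here, the two measured steps that bear on this are the ones from compound 1, and each swapped the trifluoromethyl away for a methoxy; no measured step keeps the trifluoromethyl and adds a fluorine. Compound 1, with its trifluoromethyl in place, gives 5.66 ug/mL, and the added fluorine has no measured counterpart among these compounds. The expected step is therefore a 1.1-fold lower number from compound 1 to compound 4 (0.05 log units; within the scatter), a change no larger than the scatter. Compound 4 is estimated at 5 ug/mL, with a range from 2 ug/mL to 15 ug/mL.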

Compound 4, half-maximal inhibitory concentration: 2.67 ug/mL
Estimate against measurement, compound 4: 1.9-fold (0.27 log units) above; the measured number falls inside the stated range.
By their numbers in this assay, from the lowest: compound 4; then compound 1; then compounds 3 and 2 (each within the scatter of the next).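

In this assay, within the data shown here, there is a 2.1-fold lower number from compound 1 to compound 4 (0.33 log units; beyond the scatter) when 3-fluoro-5-(trifluoromethyl)phenyl replaces 4-(trifluoromethyl)phenyl, which shows that this position still responds to a change that keeps the trifluoromethyl, whereas the earlier steps only exchanged trifluoromethyl for methoxy or compared two methoxy compounds. Set against the methoxy compounds, the same group gives a 14-fold lower number from compound 3 to compound 4 (1.13 log units; beyond the scatter) and a 14-fold lower number from compound 2 to compound 4 (1.16 log units; beyond the scatter), both larger than the steps from compound 1 to those compounds, so all the compounds with a trifluoromethyl on this ring give lower numbers than both with a methoxy, and none of the four goes against this. Nothing available here explains why the number moves in this way.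

The step to compound 4 changes the ring in two ways at once, adding a fluorine and altering where the trifluoromethyl stands, and the compounds shown cannot separate these two changes. Going by these compounds, it also stays open whether a plain phenyl, or a ring carrying a nitrile or a chlorine, would fall with compounds 1 and 4 or with compounds 2 and 3.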